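Removing the phenoxy arm from the benzyl series

The source may hold more compounds than are shown below. What is called first, only, known or untested is meant among the compounds shown, and "the series" means these compounds.

In an assay on cells for inhibition of thyroid peroxidase (Homo sapiens), with stated times of 10 min and 15 min (a lower number here means a stronger inhibitor, a higher number a weaker inhibitor), three compounds of the shared core have been measured. Compound 1 `Nc1cc(Cc2ccn(Cc3cccc(Oc4ccccc4)c3)n2)c2nn[nH]c2n1` gives 1100 nM. Compound 2 `Nc1cc(Cc2ccn(-c3ccc(F)cc3)n2)c2nn[nH]c2n1` gives 700 nM, and compound 3 `Nc1cc(Cc2ccn(-c3cccc(-c4ccccc4)c3)n2)c2nn[nH]c2n1` gives 710 nM. Compound 1 carries the highest of the three numbers, but its distances to compound 3 and to compound 2 both lie within the usual scatter, so the three are not separated by these data. Going by the values given here, no pair among them differs in a single place, so no isolated step can be drawn from them.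

Compound 4 `Nc1cc(Cc2ccn(Cc3ccccc3)n2)c2nn[nH]c2n1` remains to be measured in this assay. It differs from compound 1 by hydrogen in place of phenoxy on an aromatic carbon, the hydrogen taking the place of the phenoxy on the aromatic carbon of the six-membered aromatic ring of carbon only, meta to a large group. Nothing measured here isolates the effect of this phenoxy, so the expectation rests on the spread of the three measured numbers, all of which sit close together. The step from compound 1 to compound 4 is expected to be a 1.4-fold higher number from compound 1 to compound 4 (0.13 log units; within the scatter), towards a somewhat higher number but not clearly beyond the scatter. For compound 4 the estimate in this assay is 1500 nM, with a range from 500 nM to 4500 nM.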

Compound 4, half-maximal inhibitory concentration: 2300 nM
Compound 4: middle estimate off by 1.5-fold (0.19 log units), on the low side, within the range that was stated.
By their numbers in this assay, from the lowest: compounds 2, 3 and 1 (each within the scatter of the next); then compound 4.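

In this assay, going by these compounds alone, the step from the phenoxy compound gives the first isolated reading at this position (a 2.1-fold higher number from compound 1 to compound 4 (0.32 log units; beyond the scatter)): hydrogen in place of phenoxy on an aromatic carbon, meta to a large group, is a modest change but not a neutral one. The second new step, with benzyl in place of 4-fluorophenyl on an aromatic nitrogen (a 3.3-fold higher number from compound 2 to compound 4 (0.52 log units; beyond the scatter)), is also modest and runs the same way, so compound 4 now stands apart from both compound 1 and compound 2, a separation that the three earlier numbers did not show. No supporting measurement bears on the origin of either step, and they stand as observations only.

The compounds shown leave open whether a smaller group on the same aromatic carbon, such as methoxy, or a charged one, such as a carboxylic acid, would keep the number of compound 1 or fall back towards that of compound 4. Also open, on these data alone, is how a longer chain in place of the benzyl link on the aromatic nitrogen would read in this assay, and whether the phenoxy step holds on other parts of the series.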